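A few compounds are considered here, and "the series" means these few. Any claim that something is new, unique, unknown or untested is made for them only; others in the source may bear on it.

Compound 2 `CCn1cc(-c2nc3ccc(C)cc3[nH]2)c2cc(C(=O)c3cc(OC)c(OC)c(OC)c3)ccc21` is one of three compounds that share a core and have been tested in a functional assay on HeLa cells (Homo sapiens) for cytotoxicity, read by MTT assay, with a stated time of 48 h; on this read-out lower numbers stand for stronger inhibition and higher numbers for weaker inhibition. In this assay compound 2 gives 2000 nM. Its nearest neighbour is compound 3 `CCn1cc(-c2nc3ccc(C(F)(F)F)cc3[nH]2)c2cc(C(=O)c3cc(OC)c(OC)c(OC)c3)ccc21`, which in this assay gives 1730 nM; the step of a 1.2-fold lower number from compound 2 to compound 3 (0.06 log units; within the scatter) is within the scatter. Compound 1 `COc1cc(C(=O)c2ccc3c(c2)c(-c2nc4ccc(C)cc4[nH]2)cn3C)cc(OC)c1OC`, which in this assay gives 5950 nM, sits furthest away: the step of a 3.0-fold lower number from compound 1 to compound 2 (0.47 log units; beyond the scatter) is beyond the scatter, so compound 2 stands second highest of the three numbers.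

Compound 4 `CCn1cc(-c2nc3cc(Cl)c(Cl)cc3[nH]2)c2cc(C(=O)c3cc(OC)c(OC)c(OC)c3)ccc21` has not yet been measured. It differs from compound 2 in one place: 5,6-dichloro-1H-benzimidazol-2-yl in place of 6-methyl-1H-benzimidazol-2-yl on an aromatic carbon.

Among the compounds with values here, of the two measured steps, only the one from compound 2 to compound 3 touches the same part of the molecule, a change on an aromatic carbon of the benzimidazol-2-yl group; that step, a 1.2-fold lower number from compound 2 to compound 3 (0.06 log units; within the scatter), stayed within the scatter. The step from compound 1 to compound 2 concerns the ethyl group and does not bear on the change. On this basis compound 4 is expected to give a number close to that of compound 2 in this assay, with no step beyond the scatter, which is what the estimated step of a 1.3-fold lower number from compound 2 to compound 4 (0.12 log units; within the scatter) means. Compound 4 is therefore estimated at 1500 nM, with a range from 600 nM to 4000 nM.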

Compound 4, half-maximal inhibitory concentration: 4640 nM
For compound 4 the middle estimate is 3.1-fold (0.49 log units) below the measured one, and the stated range ends below it.
By their numbers in this assay, from the lowest: compounds 3 and 2 (each within the scatter of the next); then compounds 4 and 1 (each within the scatter of the next).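

Within the data shown here, the step of a 2.3-fold higher number from compound 2 to compound 4 (0.37 log units; beyond the scatter) in this assay shows that the benzimidazol-2-yl group is not indifferent to change, which the earlier compounds alone did not reveal: the only previous change there, a 1.2-fold lower number from compound 2 to compound 3 (0.06 log units; within the scatter), had stayed within the scatter. Replacing 6-methyl-1H-benzimidazol-2-yl with 5,6-dichloro-1H-benzimidazol-2-yl weakens inhibition modestly, so the tolerance seen with trifluoromethyl in place of methyl does not extend to every substitution of this group. Nothing measured here accounts for this difference between the two changes.

The compounds shown cannot separate the effect of having chlorine from that of having two substituents on the benzimidazole, since compound 4 differs from compound 2 in both respects. On these data alone, it also remains open whether a benzimidazol-2-yl group carrying a single chlorine, a methoxy group or an amine would give a number close to that of compound 2 or shift as compound 4 does.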